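The compounds below may be only part of what the source reports. "The series", "measured", "known", "first", "only" and "open" are said of these compounds alone.

Measured in a functional assay on UACC-62 cells (Homo sapiens); on this read-out lower numbers stand for stronger inhibition of growth and higher numbers for weaker inhibition of growth:
- Compound 1 `N#Cc1ccc(/C=C/S(=O)(=O)Cc2ccc(Nc3ncnc4ccccc34)cc2)cc1`: > 100000 nM, a limit of the assay
- Compound 2 `O=S(=O)(/C=C/c1ccc(C(F)(F)F)cc1F)Cc1ccc(Nc2ncnc3ccccc23)cc1`: 100000 nM

Within the data shown here, compound 2 holds the only actual number, 100000 nM. The reading for compound 1 is only a limit: the limit of > 100000 nM in this assay, at which 1 of the 2 values shown sits. Among the measured compounds shown here, the one measured step, a number no higher from compound 1 to compound 2 (the limit leaves the size open), therefore has no readable size.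

Compound 3 `O=S(=O)(/C=C/c1ccc(C(F)(F)F)cc1F)Cc1ccc(Nc2ncnc3cc(Cl)ccc23)cc1` carries chloro in place of hydrogen on an aromatic carbon, quinazolin-4-yl to 7-chloroquinazolin-4-yl: chloro in place of hydrogen on an aromatic carbon. The measured step concerns a different group and gives no guide to the size of this change. With compound 2 at 100000 nM, the number has little room to rise in this assay, so a lower number is the likelier direction. The expected change is a 3.3-fold lower number from compound 2 to compound 3 (0.52 log units; beyond the scatter), an estimate held loosely. For compound 3 the estimated value is 30000 nM, with an expected range of 3000 nM to 100000 nM.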

Compound 3, concentration for 50% growth inhibition: > 100000 nM
Compound 3: no number, only a limit; the forecaster's own chance of this, stated with the estimate: 30%; at least 3.3-fold (0.52 log units) between middle value and limit.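

Chloro in place of hydrogen, quinazolin-4-yl to 7-chloroquinazolin-4-yl, is the first change shown on this part of the core, and in this assay it brings no measurable gain in growth inhibition. Among these compounds, the one new step, a number no lower from compound 2 to compound 3 (the limit leaves the size open), cannot be read for size, so a small loss and a large one look the same here. Most of the series now reads only as a limit, which leaves little to compare: the limit of > 100000 nM in this assay, at which 2 of the 3 values shown sit.

Still open, going by these compounds, is whether any change on this aromatic carbon gives a real number well inside the range of the assay. An amine or a methoxy group in place of the chloro, on the same carbon, might read differently, but the compounds shown do not say.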